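Rat plasma clearance: replacing the benzylic amine of compound 2

The compounds below may be only part of what the source reports. "The series", "measured", "known", "first", "only" and "open" are said of these compounds alone.

Compound 2 `CC[C@H](C)N1C(=O)C(C)(C)c2cnc(Nc3ccc(CN4CC(C)OC(C)C4)cc3)nc21` sits at the top of the three numbers in an ADME assay on a cell-free system (plasma, Rattus norvegicus) for pharmacokinetics (a lower number here means slower removal, a higher number faster removal of the compound), with 269 mL/min/kg, though compound 1 `C[C@@H](c1ccc(F)cc1)N1C(=O)C(C)(C)c2cnc(Nc3cccnc3)nc21` at 154 mL/min/kg lies within the scatter of it; compound 3 `CC1(C)C(=O)N(C2CCCCC2)c2nc(Nc3cccnc3)ncc21` at 47 mL/min/kg is the furthest away, beyond the scatter. Among the measured compounds shown here, the only measured step, a 3.3-fold lower number from compound 1 to compound 3 (0.52 log units; beyond the scatter), changes the group on the amide-type nitrogen in the ring. Compound 4 `CC[C@H](C)N1C(=O)C(C)(C)c2cnc(Nc3ccc(CNC4CCCOC4)cc3)nc21` alters the other end of the molecule instead: (oxan-3-yl)amino in place of 2,6-dimethylmorpholin-4-yl on a saturated chain carbon bound to an aromatic carbon. For the measured compounds named here, no measured step touches this position, so the measured step gives no direct guide. With nothing else to go on, compound 4 is expected to stay close to its parent, a 1.2-fold lower number from compound 2 to compound 4 (0.09 log units; within the scatter), within the scatter. The estimate for compound 4 in this assay is 220 mL/min/kg, with a range from 100 mL/min/kg to 450 mL/min/kg.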

Compound 4, clearance: 188 mL/min/kg
Estimate against measurement, compound 4: 1.2-fold (0.07 log units) above, within the range that was stated.
By their numbers in this assay, from the lowest: compound 3; then compounds 1, 4 and 2 (each within the scatter of the next).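

In this assay, among the compounds shown here, the first change at this position gives a 1.4-fold lower number from compound 2 to compound 4 (0.16 log units; within the scatter) and so stays within the scatter. Going from 2,6-dimethylmorpholin-4-yl to (oxan-3-yl)amino, with 1 hydrogen-bond donor where there were 0, therefore moves the clearance no further than repeat measurements would, unlike the change on the amide-type nitrogen. Nothing available accounts for this result.

On these data alone, whether a carboxylic acid or a primary amine on this saturated chain carbon would give a step beyond the scatter remains open. Also open, as far as these compounds go, is whether (oxan-3-yl)amino behaves alike with cyclohexyl on the amide-type nitrogen.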